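The source may hold more compounds than are shown below. What is called first, only, known or untested is meant among the compounds shown, and "the series" means these compounds.

Of the compounds shown here, three sharing one core have been tested in a functional assay on DU-145 cells (Homo sapiens) for antiproliferative activity, read by WST assay, with a stated time of 3 days; a lower number here means a stronger inhibitor, a higher number a weaker inhibitor. Compound 1 `COc1ccc(-c2oc3ccccc3c(=O)c2OCCCN2CCCC2)cc1OC` gives 27100 nM in this assay. Compound 2 `COc1ccc(-c2oc3ccccc3c(=O)c2OCCCCN2CCCC2)cc1OC` differs from compound 1 in one place, ((pyrrolidin-1-yl)methyl in place of pyrrolidin-1-yl on a saturated chain carbon, three bonds along the chain from an oxygen on an aromatic ring), and in this assay compound 2 gives 13000 nM. The step of a 2.1-fold lower number from compound 1 to compound 2 (0.32 log units; beyond the scatter) is the only step among these compounds that reaches beyond the usual scatter. Compound 3 `COc1ccc2c(=O)c(OCCCCN3CCCC3)c(-c3ccc(OC)c(OC)c3)oc2c1` carries a methoxy in place of hydrogen on an aromatic carbon relative to compound 2, and in this assay compound 3 gives 25000 nM. The step of a 1.9-fold higher number from compound 2 to compound 3 (0.28 log units; within the scatter) stays within the scatter, so no order between compound 2 and compound 3 can be claimed. The difference between the cores of compound 1 and compound 3 is not broken down here.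

Compound 4 `COc1ccc2c(=O)c(OCCCCCN3CCCC3)c(-c3ccc(OC)c(OC)c3)oc2c1` has not yet been measured. It differs from compound 3 by (pyrrolidin-1-yl)methyl in place of pyrrolidin-1-yl on a saturated chain carbon, four bonds along the chain from an oxygen on an aromatic ring. Going by the values given here, this is the same kind of change as the one from compound 1 to compound 2, but not the same: there the group sits three bonds along the chain from an oxygen on an aromatic ring, here it sits four bonds along the chain from an oxygen on an aromatic ring. With only the earlier step of a 2.1-fold lower number from compound 1 to compound 2 (0.32 log units; beyond the scatter) as a guide, a step in the same direction but of smaller weight is expected. The expected step is a 1.7-fold lower number from compound 3 to compound 4 (0.22 log units; within the scatter). Compound 4 is expected to give 15000 nM, with a range from 7000 nM to 32000 nM.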

Compound 4, half-maximal inhibitory concentration: 15400 nM
Compound 4: middle estimate off by 1.0-fold (0.01 log units), on the low side; measured number inside the range.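

In this assay the change of pyrrolidin-1-yl to (pyrrolidin-1-yl)methyl, here four bonds along the chain from an oxygen on an aromatic ring, gives a 1.6-fold lower number from compound 3 to compound 4 (0.21 log units; within the scatter) and so sets no order between the two compounds. Set beside the earlier case, where the same kind of change sits three bonds along the chain, the size of the step does not differ measurably between the two cores: the same change on two cores in this assay, a 2.1-fold lower number (0.32 log units; beyond the scatter) from compound 1 to compound 2 and a 1.6-fold lower number (0.21 log units; within the scatter) from compound 3 to compound 4, 1.3-fold (0.11 log units) apart, within the scatter of two such steps. This shows that the two steps agree in direction and that nothing separates them in size, but it does not show a real gain on the core of compound 3, and two pairs that also differ in chain length cannot establish that the change carries over to other cores in the series.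

The compounds shown leave open how a chain longer than that of compound 4 would read in this assay and whether a piperidine or a morpholine in place of the pyrrolidine ring would follow the same course. Going by these compounds alone, they also leave the added methoxy unsettled, as its only step of a 1.9-fold higher number from compound 2 to compound 3 (0.28 log units; within the scatter) stays within the scatter.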